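This account rests on a few compounds, and the source may have more. Where it says the series, first, only, none or still open, it means among the compounds named here.

Within the data shown here, in an in vivo functional assay on the whole organism for inhibition of sorbitol dehydrogenase (Rattus norvegicus), at a dose of 10 mg/kg by the oral route (on this read-out higher numbers stand for more inhibition at the one dose given (going by the name of the read-out) and lower numbers for less inhibition), compound 2 `O=C(O)Cc1nn(Cc2nc3cc(Cl)cc(Cl)c3s2)c(=O)c2ccccc12` gives 73%, the highest of the two numbers measured so far, while compound 1 `O=C(O)Cc1nn(Cc2nc3cccc(Cl)c3s2)c(=O)c2ccccc12` gives 52%. Among the measured compounds shown here, the single measured step, a number 21 percentage points higher from compound 1 to compound 2 (beyond the scatter), is modest but beyond the scatter. Compound 3 `O=C(O)Cc1nn(Cc2nc3cc(C(F)(F)F)cc(Cl)c3s2)c(=O)c2ccccc12` differs from compound 2 by trifluoromethyl in place of chloro on an aromatic carbon. For the measured compounds named here, no measured step swaps one such group for another, so there is little to go on beyond the fact that compound 2 already carries a group there; the expected step of a number 8 percentage points lower from compound 2 to compound 3 (within the scatter) is therefore small, within the scatter. Compound 3 is estimated at 65%, with a range from 40% to 85%.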

Compound 3, a percentage reported as inhibition, in the whole organism at one dose (the size of the read-out at that dose, not a potency): 26%
Compound 3: the middle estimate sits 39 percentage points above what was measured, outside the stated range (below it).
By their numbers in this assay, from the lowest: compound 3; then compound 1; then compound 2.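

In this assay, trifluoromethyl in place of chloro at this position gives a number 47 percentage points lower from compound 2 to compound 3 (beyond the scatter), so the result depends strongly on which group sits there. Measured against hydrogen, trifluoromethyl gives a number 26 percentage points lower from compound 1 to compound 3 (beyond the scatter), whereas chloro gave a higher number, so putting just any group at this position does not raise the number. Nothing available here explains this drop.

On these data alone, whether fluoro, methyl or methoxy at this position would track chloro or trifluoromethyl remains open. So does whether the drop would persist without the other chloro group.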